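The source may hold more compounds than are shown below. What is called first, only, known or untested is meant among the compounds shown, and "the series" means these compounds.

Compound 1, `Cc1ccc(N2C(=O)COc3ccc(-c4cnc5ccccc5c4)cc32)cc1`: > 40000 nM
Compound 2, `O=C1COc2ccc(-c3cnc(Cl)c(NS(=O)(=O)c4ccc(F)cc4)c3)cc2N1c1ccccc1`: 14700 nM

Going by the values given here, in a functional assay on A549 cells (Homo sapiens) for antiproliferative activity, read by MTT assay, with a stated time of 72 h (on this read-out higher numbers stand for weaker inhibition and lower numbers for stronger inhibition), compound 2 gives 14700 nM, the only number available in this set. For compound 1 the assay reports only a limit, (the limit of > 40000 nM in this assay, at which 1 of the 2 values shown sits). Compound 3, `O=C1COc2ccc(-c3cnc(Cl)c(NS(=O)(=O)c4ccc(F)cc4)c3)cc2N1C1CC1`, differs from compound 2 in one place: cyclopropyl in place of phenyl on an amide-type nitrogen in a ring. Among the compounds with values here, no step between two measured compounds is available to guide the change, so its direction is open; the expected step in this assay is a 1.4-fold higher number from compound 2 to compound 3 (0.13 log units; within the scatter), not beyond the scatter of repeats. Compound 3 is estimated at 20000 nM, with a range from 5000 nM to 60000 nM.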

Compound 3, half-maximal inhibitory concentration: 4330 nM
Compound 3: the middle estimate sits 4.6-fold (0.66 log units) above what was measured; measured number outside the range, below it.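

In this assay the group on the amide-type nitrogen in a ring turns out to matter: cyclopropyl in place of phenyl gives a 3.4-fold lower number from compound 2 to compound 3 (0.53 log units; beyond the scatter), a modest step. Phenyl is therefore not required at this place, and a group of 3 heavy atoms serves better here than one of 6. No measurement shown accounts for this step. As far as these compounds go, whether methyl, a longer chain or a chain carrying an amine would match cyclopropyl remains open. So does whether the step would hold on another core.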